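Ring Arm Traded for tert-Butyl: Cytotoxicity Outlook

This account rests on a few compounds, and the source may have more. Where it says the series, first, only, none or still open, it means among the compounds named here.

Among the measured compounds shown here, the three compounds measured so far share one core and differ only in the side arm. In an ADME assay on CRL8155 cells (Homo sapiens) for cytotoxicity, read by resazurin assay, with a stated time of 72 h (on this read-out lower numbers stand for an effect already at smaller amounts and higher numbers for an effect only at larger amounts of compound), compound 1 `NCCCC(=O)Nc1nc2ccc(C(=O)c3ccccc3)cc2[nH]1` gives > 30000 nM, which is a limit of the measurement rather than a number. Compound 2 `NCCCCCCC(=O)Nc1nc2ccc(C(=O)c3ccccc3)cc2[nH]1` also reaches only a limit, > 30000 nM, in this assay. Compound 3 `Nc1nc2ccc(C(=O)c3ccccc3)cc2n1C[C@H]1CCCN1` likewise stops at a limit, > 30000 nM, in this assay. For the measured compounds named here, the one measured step, a step that the two limits leave unreadable from compound 1 to compound 2, therefore cannot be read. Compound 3 thus stands where all of its companions stand, because of the limit of > 30000 nM in this assay, at which 3 of the 3 values shown sit.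

Compound 4 `CC(C)(C)Cn1c(N)nc2ccc(C(=O)c3ccccc3)cc21` differs from compound 3 in one place: tert-butyl in place of pyrrolidin-2-yl on a saturated chain carbon bound to an aromatic nitrogen. Going by the values given here, no measured step bears on this change, since the only recorded step is unreadable and the side arms measured all end at the same limit. No step beyond the scatter is expected, so the step from compound 3 to compound 4 is estimated as a number no higher from compound 3 to compound 4 (the limit leaves the size open). Compound 4 is expected to give 30000 nM in this assay, most likely again as a limit rather than a number.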

Compound 4, half-maximal effective concentration: > 30000 nM
Compound 4 ended at the assay's limit; the forecaster's own chance of this, stated with the estimate: 80%; the middle value sits exactly at the limit.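

In this assay compound 4 also stops at a limit, so the step from compound 3 to compound 4 cannot be read: the limit of > 30000 nM in this assay, at which 4 of the 4 values shown sit.

The compounds shown leave open how far apart they truly lie, and whether any of them would show cytotoxicity at larger amounts.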